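From compound 2 to compound 3: aryl for alkyl

The source may report more compounds than this note shows. Statements on the series, on what has been measured and on what is new or still open speak of the compounds shown alone.

The series shares one core carrying two amine substituents. Compound 1 `Fc1cc(F)c(Nc2nc3nonc3nc2Nc2c(F)cc(F)cc2F)c(F)c1` bears a fluorinated aryl group on each nitrogen; in an assay on mitochondria from L6 cells (Rattus norvegicus) for activation, with a stated time of 90 min (a higher number here means that more compound is needed for the effect, a lower number that less compound is needed), compound 1 gives 1100 nM. Compound 2 `Fc1ccccc1Nc1nc2nonc2nc1NCCC(F)(F)F` carries 3,3,3-trifluoropropyl on one nitrogen instead. In this assay compound 2 gives > 100000 nM, which is a limit of the assay and not a number. Compound 2 thus stands at the limit of > 100000 nM in this assay, at which 1 of the 2 values shown sits. Compound 3 `CCOc1cccc(Nc2nc3nonc3nc2Nc2ccccc2F)c1` is the next compound to be measured. It differs from compound 2 by 3-ethoxyphenyl in place of 3,3,3-trifluoropropyl on a nitrogen on an aromatic ring. For the measured compounds named here, no step between measured compounds is recorded. Compound 1, with an aryl group on each nitrogen, reaches a measurable number, whereas compound 2 does not. The step is therefore expected to be large and towards less compound needed, estimated as an at least 33-fold lower number from compound 2 to compound 3 (1.52 log units; beyond the scatter). Compound 3 is expected at 3000 nM, within 500 nM to 30000 nM.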

Compound 3, half-maximal effective concentration: 2200 nM
Compound 3: the middle estimate sits 1.4-fold (0.13 log units) above what was measured, within the range that was stated.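

In this assay, for the compounds shown here, the only step between compounds that differ in one place is an at least 45-fold lower number from compound 2 to compound 3 (1.65 log units; beyond the scatter), so the substituent on this nitrogen alone can move the series from a limit of the assay to a measurable number. As far as these compounds go, compound 2 gives > 100000 nM, which is a limit of the assay and not a number, so the true size of the step stays unknown: the limit of > 100000 nM in this assay, at which 1 of the 3 values shown sits. On this single pair, 3-ethoxyphenyl on this nitrogen gives a measurable number, whereas 3,3,3-trifluoropropyl does not.

Whether the aromatic ring or its ethoxy group accounts for the step remains open, and plain phenyl or 3-methoxyphenyl would help separate the two. Also open, from the compounds shown here alone, is how a longer alkyl chain or an amine-bearing chain would behave at this nitrogen.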